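Adding a methoxy group to the pyridin-3-yl of compound 2

A few compounds are considered here, and "the series" means these few. Any claim that something is new, unique, unknown or untested is made for them only; others in the source may bear on it.

Measured so far in a functional assay on the whole organism for inhibition, with Rattus norvegicus as the target, read by cytopathic effect and paw edema, at a dose of 100 mg/kg by the oral route; on this read-out lower numbers stand for less inhibition and higher numbers for more inhibition at the one dose given (going by the name of the read-out):
compound 1 (`O=C(NN1CCOCC1)c1c(O)c2cccnc2n(-c2ccccc2)c1=O`) gives -26.2%
compound 2 (`O=C(Nc1cccnc1)c1c(O)c2cccnc2n(-c2ccccc2)c1=O`) gives 30.8%

Compound 2 stands highest of these two numbers. Going by the values given here, the only measured step, a number 57 percentage points higher from compound 1 to compound 2 (beyond the scatter), came with pyridin-3-yl in place of morpholin-4-yl on an amide-type nitrogen, a swap of the whole ring.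

Compound 3 (`COc1ccc(NC(=O)c2c(O)c3cccnc3n(-c3ccccc3)c2=O)cn1`) differs from compound 2 in one place: methoxy in place of hydrogen on an aromatic carbon. This change keeps the pyridin-3-yl ring and adds only a methoxy group. Among the compounds with values here, no measured pair shows what adding methoxy does here, so the single measured step, which exchanged one ring for another, does not bear directly on it. With no guidance, the expected step is none beyond the scatter, that is a number 0.8 percentage points lower from compound 2 to compound 3 (within the scatter). Compound 3 is therefore expected to give 30%, with a range from 10% to 50%.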

Compound 3, a percentage reported as inhibition, in the whole organism at one dose (the size of the read-out at that dose, not a potency): -10.2%
Compound 3: middle estimate off by 40.2 percentage points, on the high side; the measured number lies below the stated range.
By their numbers in this assay, from the lowest: compound 1; then compound 3; then compound 2.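

In this assay, the aromatic carbon next to the ring nitrogen and para to a large group proves highly sensitive to substitution: adding methoxy there gives a number 41 percentage points lower from compound 2 to compound 3 (beyond the scatter) in a single change. Even so, the gain over the morpholin-4-yl amide is not wholly lost, since the 6-methoxypyridin-3-yl amide still gives a number 16 percentage points higher from compound 1 to compound 3 (beyond the scatter) as a modest step beyond the scatter. No measurement bearing on this result offers a reason for the fall.

From the compounds shown here alone, whether any added group at this carbon lowers the number, or methoxy in particular, remains open, and fluorine, methyl or an amine at the same place would help separate the two. Going by these compounds, it is also open whether methoxy on another carbon of the pyridine ring would give a similar step.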